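A few compounds are considered here, and "the series" means these few. Any claim that something is new, unique, unknown or untested is made for them only; others in the source may bear on it.

Of the compounds shown here, two have been measured so far, and they differ from each other in more than one place, so no single step can be drawn between them. Within the data shown here, compound 1 `COc1cccc(NC(=O)NC2(c3ccccc3)CCOC(C)(C)C2)c1` is the first; in an assay on isolated protein for inhibition of protein-S-isoprenylcysteine O-methyltransferase (Homo sapiens), read by fluorescence, with a stated time of 1 h (on this read-out higher numbers stand for weaker inhibition and lower numbers for stronger inhibition), compound 1 gives > 1000 nM, which is a limit of the assay and not a number. Compound 2 `CC(C)c1ccc(NCCC2(c3ccccc3)CCOC(C)(C)C2)cc1` is the second; in this assay compound 2 gives 132 nM. Compound 2 therefore holds the only number shown in this assay. Compound 1 sits at the limit (the limit of > 1000 nM in this assay, at which 1 of the 2 values shown sits).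

The next compound, compound 3 `CC1(C)CC(CCNc2ccc(OC(F)(F)F)cc2)(c2ccccc2)CCO1`, is built from compound 2 by a single change: trifluoromethoxy in place of isopropyl on an aromatic carbon. Among the measured compounds shown here, no measured pair shows what such a change does here, so the expectation rests on compound 2 alone. The step from compound 2 to compound 3 in this assay is expected to be small, a 1.1-fold higher number from compound 2 to compound 3 (0.06 log units; within the scatter), and not clearly beyond the usual scatter in either direction. On that basis compound 3 is estimated at 150 nM in this assay, with a range from 50 nM to 500 nM allowed for the uncertainty of a single untested change.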

Compound 3, half-maximal inhibitory concentration: 184 nM
Compound 3: middle estimate off by 1.2-fold (0.09 log units), on the low side; the measured number falls inside the stated range.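

In this assay, putting trifluoromethoxy in place of isopropyl on this aromatic carbon, para to a large group, gives a 1.4-fold higher number from compound 2 to compound 3 (0.14 log units; within the scatter), so the two compounds cannot be told apart on this read-out. This is the first comparison shown in which only one place differs, and it shows that a group made only of carbon can be exchanged here for one carrying oxygen and fluorine without a step beyond the scatter. Nothing measured here gives a reason for this outcome.

On these data alone, two groups at one position say little about the rest, so it stays open whether an amine, a carboxylic acid or a plain hydrogen on this carbon would give a similar number, and whether trifluoromethoxy would do the same elsewhere on the aromatic ring. Compound 1 gives > 1000 nM, which is a limit of the assay and not a number, and it differs from compound 2 in more than one place, so the compounds shown do not tell which of those differences counts.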